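Halogen pattern on the anilino ring and cell inhibition

The source may hold more compounds than are shown below. What is called first, only, known or untested is meant among the compounds shown, and "the series" means these compounds.

Compound 2 `Cc1n[nH]c2ccc(-c3nc4cnc(N5CCN(C)CC5)cn4c3Nc3ccc(Br)cc3)cc12`: 83%
Compound 1 `Cc1n[nH]c2ccc(-c3nc4cnc(N5CCN(C)CC5)cn4c3Nc3cccc(Cl)c3)cc12`: 0%

In a functional assay on MV4-11 cells (Homo sapiens) for inhibition, with a stated time of 120 h, tested at 10 uM (a higher number here means more inhibition at the concentration tested (going by the name of the read-out), a lower number less inhibition), compound 2 gives 83%, the highest of the two numbers, while compound 1 gives 0%. Within the data shown here, the only measured step, a number 83 percentage points higher from compound 1 to compound 2 (beyond the scatter), shows that the halogen pattern on this ring matters greatly. Compound 3 `Cc1n[nH]c2ccc(-c3nc4cnc(N5CCN(C)CC5)cn4c3Nc3ccc(F)cc3Br)cc12` carries 2-bromo-4-fluorophenyl in place of 4-bromophenyl on a nitrogen on an aromatic ring. Among the measured compounds shown here, no measured step covers this exact change, so the direction is uncertain; a moderate loss is expected, with a number 33 percentage points lower from compound 2 to compound 3 (beyond the scatter). Compound 3 is estimated at 50%, ranging from 10% to 85%.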

Compound 3, a percentage reported as inhibition, at one concentration (the size of the read-out at that concentration, not a potency): 82.4%
Beside the measured number, compound 3's estimate is 32.4 percentage points below it; the range from low to high includes it.
By their numbers in this assay, from the lowest: compound 1; then compounds 3 and 2 (each within the scatter of the next).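

In this assay, the change to 2-bromo-4-fluorophenyl gives a number 0.6 percentage points lower from compound 2 to compound 3 (within the scatter), so this position accepts a second bromine-bearing pattern with a fluorine added and no readable change. The step of a number 82.4 percentage points higher from compound 1 to compound 3 (beyond the scatter) shows that the gap to 3-chlorophenyl is not unique to 4-bromophenyl. Nothing at hand explains these differences. The compounds shown do not separate the identity of the halogen from its place on the ring, as a 4-chlorophenyl or 3-bromophenyl group would. From the compounds shown here alone, how an unsubstituted phenyl or a methoxy-bearing phenyl on this nitrogen would behave also remains open.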